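This account rests on a few compounds, and the source may have more. Where it says the series, first, only, none or still open, it means among the compounds named here.

Of the compounds shown here, two on the shared core have been read so far. Compound 1 `NCCCOc1ccc([C@H]2CC[C@]3(CC2)OOC2(O3)C3CC4CC(C3)CC2C4)cc1` gives < 7 mL.min-1.g-1 in an ADME assay on microsomes from liver (Mus musculus) for metabolic stability, read by LC-MS, tested at 1 uM (on this read-out higher numbers stand for fast clearance and lower numbers for slow clearance), as a limit of the assay and not a number. Among the compounds with values here, compound 2 `c1cc([C@H]2CC[C@]3(CC2)OOC2(O3)C3CC4CC(C3)CC2C4)ccc1OC1CCNCC1` gives 10 mL.min-1.g-1 as the only true number so far. Compound 3 `N[C@H]1CC[C@@H](Oc2ccc([C@H]3CC[C@]4(CC3)OOC3(O4)C4CC5CC(C4)CC3C5)cc2)CC1` is not yet measured, and its difference from compound 2 4-aminocyclohexyl in place of piperidin-4-yl on an oxygen on an aromatic ring is 4-aminocyclohexyl in place of piperidin-4-yl on an oxygen on an aromatic ring. Within the data shown here, one measured step bears on this change, at the same place, and it starts from the limit of < 7 mL.min-1.g-1 in this assay, at which 1 of the 2 values shown sits, so that it gives a floor and not a size. No real shift in this assay is expected for compound 3 because an at least 1.4-fold higher number from compound 1 to compound 2 (0.15 log units; that floor lies within the scatter) has a floor inside the scatter, and no direction is supported. The expected step is a 1.1-fold lower number from compound 2 to compound 3 (0.05 log units; within the scatter) and it is expected to stay within the scatter. For compound 3 the expected value is 9 mL.min-1.g-1 with an estimated range from 4 mL.min-1.g-1 to 22 mL.min-1.g-1 around it.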

Compound 3, intrinsic clearance in microsomes: < 7 mL.min-1.g-1
Compound 3 was reported as a limit; the forecaster's own chance of this, stated with the estimate: 35%; middle value at least 1.2-fold (0.10 log units) away from the limit.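

In this assay compound 3 gives < 7 mL.min-1.g-1, which is a limit of the assay and not a number. Replacing piperidin-4-yl with 4-aminocyclohexyl on the oxygen on the aromatic ring gives an at least 1.4-fold lower number from compound 2 to compound 3 (0.15 log units; that floor lies within the scatter), so a second change at this position has been tried, but its floor still shows no real shift and leaves the size of any shift unknown. The step between compound 1 and compound 3 cannot be read, and the position cannot yet be ranked because most of its readings rest on one limit: the limit of < 7 mL.min-1.g-1 in this assay, at which 2 of the 3 values shown sit.

Going by these compounds, it remains open whether any group on this oxygen moves clearance beyond the scatter, for example a tertiary amine, an amide or a carboxylic acid, any of which might give a true number to set against compound 2. Also unresolved is how far compound 1 and compound 3 lie from the limit, and whether a longer chain ending in an amine would read differently from 3-aminopropyl.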